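The source may report more compounds than this note shows. Statements on the series, on what has been measured and on what is new or still open speak of the compounds shown alone.

Measured compounds:
Compound 1 `O=C(NC1CCN(Cc2ccccc2)CC1)c1cc(=O)c2ccccc2o1`: 29.7%
Compound 2 `O=C(NCCC1CCN(Cc2ccccc2)CC1)c1coc2ccccc2c1=O`: 68.6%
Compound 3 `COc1ccc2c(=O)c(C(=O)NCCC3CCN(Cc4ccccc4)CC3)coc2c1`: 32.4%

In an assay on isolated protein for inhibition of Amine oxidase [flavin-containing] A (Homo sapiens), read by fluorescence and Amplex Red, with stated times of 15 min and 20 min, tested at 100 uM (a lower number here means less inhibition, a higher number more inhibition at the concentration tested (going by the name of the read-out)), compound 3 gives 32.4%. That number sits within the scatter of the value compound 1 gives, 29.7%, while compound 2 stands clearly apart with 68.6%. Compound 4 `O=C(NCCC1CCN(Cc2ccccc2)CC1)c1coc2cc(Br)ccc2c1=O` is the next compound in this series, and it differs from compound 3 in one place: bromo in place of methoxy on an aromatic carbon.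

Among the compounds with values here, only one measured step speaks to this change. The step of a number 36.2 percentage points lower from compound 2 to compound 3 (beyond the scatter) shows that putting a methoxy onto that aromatic carbon of the shared core cut inhibition heavily. Within the data shown here, compound 4 takes the methoxy away again, but it puts a bromo there instead, and no bromo-bearing compound has been measured, so how much of the loss is recovered is open. It is therefore expected that compound 4 will land between compound 3 and compound 2, with a number 17.6 percentage points higher from compound 3 to compound 4 (beyond the scatter) as an upward step. The estimate for compound 4 is 50%, with a range from 25% to 75%.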

Compound 4, a percentage reported as inhibition, at one concentration (the size of the read-out at that concentration, not a potency): 30.3%
Compound 4: middle estimate off by 19.7 percentage points, on the high side; the range from low to high includes it.
By their numbers in this assay, from the lowest: compounds 1, 4 and 3 (each within the scatter of the next); then compound 2.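

In this assay, bromo in place of methoxy on this aromatic carbon gives a number 2.1 percentage points lower from compound 3 to compound 4 (within the scatter) and so leaves the number unchanged within the scatter. Bromo in place of hydrogen gives a number 38.3 percentage points lower from compound 2 to compound 4 (beyond the scatter) and methoxy in place of hydrogen gives a number 36.2 percentage points lower from compound 2 to compound 3 (beyond the scatter) so the large loss at this place is not confined to methoxy, as the earlier compounds alone could not show. Nothing available explains why these two different groups give such similar numbers.

From the compounds shown here alone, whether any group on this carbon can keep inhibition near the 68.6% of compound 2 remains open, and fluoro, hydroxyl and an amine are untested here. The compounds shown also leave open whether bromo has the same effect on any other carbon of this ring.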